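The source may report more compounds than this note shows. Statements on the series, on what has been measured and on what is new or still open speak of the compounds shown alone.

In a functional assay, with a stated time of 30 min (on this read-out lower numbers stand for stronger inhibition and higher numbers for weaker inhibition), compound 1 (`O=C(/C=C/c1ccc(O)cc1)CC(=O)/C=C/c1cccc(O)c1O`) gives 27000 nM. Compound 2 (`O=C(/C=C/c1ccc(O)c(O)c1)/C=C/c1ccccc1O`) gives 62000 nM, the higher of the two numbers and so the weaker inhibition, and the gap between them lies beyond the usual scatter of repeat measurements. These two compounds differ in more than one place, so their values do not isolate the effect of any single change.

Compound 3 (`O=C(/C=C/c1cccc(O)c1)/C=C/c1ccc(O)c(O)c1`) has not yet been measured. It has the same atoms as compound 2, joined differently: 3-hydroxyphenyl in place of 2-hydroxyphenyl on a double-bonded chain carbon bound to a double-bonded chain carbon. Here 3-hydroxyphenyl stands in place of 2-hydroxyphenyl on a double-bonded chain carbon bound to a double-bonded chain carbon.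

Within the data shown here, no measured step shows what this swap does, so the forecast is cautious. Among the measured compounds shown here, the only other reference is compound 1 at 27000 nM, which suggests a number of similar magnitude and leans the forecast slightly downward. The expected step, a 1.6-fold lower number from compound 2 to compound 3 (0.19 log units; within the scatter), is a small one toward a lower number, and it is estimated to stay within the scatter. Compound 3 is estimated at 40000 nM, with an expected range of 13000 nM to 120000 nM.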

Compound 3, half-maximal inhibitory concentration: 71000 nM
Compound 3: middle estimate off by 1.8-fold (0.25 log units), on the low side; measured number inside the range.
By their numbers in this assay, from the lowest: compound 1; then compounds 2 and 3 (each within the scatter of the next).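

Among these compounds, compound 2 and compound 3 form the first pair in this set that differs in only one place, so this is the first direct look at a single change. In this assay, putting 3-hydroxyphenyl in place of 2-hydroxyphenyl on a double-bonded chain carbon bound to a double-bonded chain carbon gives a 1.1-fold higher number from compound 2 to compound 3 (0.06 log units; within the scatter) and so leaves the two compounds indistinguishable on this read-out; for this pair, at this place, the two hydroxyphenyl groups cannot be told apart, although this says nothing about other changes or other cores. Nothing further is available that would explain this result.

From the compounds shown here alone, the comparison covers only these two hydroxyphenyl groups, so it remains open whether the number would hold with a plain phenyl ring, a methoxyphenyl group, or a phenyl ring carrying an amine or a carboxylic acid at the same place. Going by these compounds, compound 1 still differs from compound 2 and compound 3 in more than one place, so what sets its number apart from theirs also remains open.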